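The source may report more compounds than this note shows. Statements on the series, on what has been measured and on what is new or still open speak of the compounds shown alone.

In a functional assay on MDA-MB-231 cells (Homo sapiens) for antiproliferative activity, read by CCK-8 assay, with a stated time of 48 h; a higher number here means a weaker inhibitor, a lower number a stronger inhibitor:
compound 1 `C=CC(=O)NCCOc1ccc(Oc2c(-c3ccc(F)cc3)sc3cc(O)ccc23)cc1` — > 50000 nM, a limit of the assay, not a number.
compound 2 `O=C(/C=C/CN1CC(Oc2ccc(Oc3c(-c4ccc(F)cc4)sc4cc(O)ccc34)cc2)C1)N1CCCC1` — > 50000 nM, likewise a limit.
compound 3 `O=C(/C=C/CN1CC(Oc2ccc(Oc3c(-c4ccc(F)cc4)sc4cc(O)ccc34)cc2)C1)N1CCC1` — > 50000 nM, likewise a limit.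

Compound 1 therefore stands only at the limit of this assay, with no number to place it against the other two. Compound 4 `CN(C)C(=O)/C=C/CN1CC(Oc2ccc(Oc3c(-c4ccc(F)cc4)sc4cc(O)ccc34)cc2)C1` differs from compound 1 by 1-(3-(dimethylcarbamoyl)prop-2-en-1-yl)azetidin-3-yl in place of 2-((vinylcarbonyl)amino)ethyl on an oxygen on an aromatic ring. Going by the values given here, the one measured step in this assay, a step that the two limits leave unreadable from compound 2 to compound 3, concerns only the ring on the carbonyl carbon and is itself unreadable, so it cannot give a size or direction for the change from compound 1 to compound 4. The whole picture is the limit of > 50000 nM in this assay, at which 3 of the 3 values shown sit. Among the compounds with values here, no step in this assay is expected beyond the limit. Compound 4 is expected to report a limit as well, estimated at 70000 nM with a range of 30000 nM to 300000 nM. The implied step that the limit leaves unreadable from compound 1 to compound 4 is expected to remain unreadable.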

Compound 4, half-maximal inhibitory concentration: > 50000 nM
Compound 4 ended at the assay's limit; the forecaster's own chance of this, stated with the estimate: 85%; the middle value lies beyond the limit too.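

In this assay compound 4 gives > 50000 nM, a limit and not a number, so its steps from compound 1, compound 2 and compound 3 cannot be read. Going by these compounds, how these four compounds rank against each other, and whether any of the changes among them alters activity, stays open.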